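Amide variation on the naphthol-triazole thioether core

A few compounds are considered here, and "the series" means these few. Any claim that something is new, unique, unknown or untested is made for them only; others in the source may bear on it.

Measured compounds:
compound 1, `O=C(Nc1cc(Sc2ncn[nH]2)c(O)c2ccccc12)c1cccc([N+](=O)[O-])c1`, 48000 nM
compound 2, `Cc1nnc(Sc2cc(NC(=O)c3ccc(Cl)cc3)c3ccccc3c2O)s1`, > 100000 nM
compound 3, `COc1ccc(/C=C/C(=O)Nc2cc(Sc3ncn[nH]3)c(O)c3ccccc23)cc1OC`, 52500 nM

Notes. In a functional assay on MDA-MB-231 cells (Homo sapiens) for antiproliferative activity, read by MTT assay, with a stated time of 48 h (a higher number here means a weaker inhibitor, a lower number a stronger inhibitor), compound 1 gives 48000 nM. Compound 3 gives 52500 nM in this assay, a number that sits within the usual scatter of that of compound 1, so the two cannot be told apart. Compound 2 reaches only the assay limit, > 100000 nM, and no number is known for it; this is the situation described by the limit of > 100000 nM in this assay, at which 1 of the 3 values shown sits. Compound 2 also carries a different thioether heterocycle and so stands apart from the shared core of compound 1 and compound 3.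

Not yet measured is compound 4, `COc1ccc(C(=O)Nc2cc(Sc3ncn[nH]3)c(O)c3ccccc23)cc1`. Relative to compound 1 the change is 4-methoxyphenyl in place of 3-nitrophenyl on a carbonyl carbon. For the measured compounds named here, no measured pair shows the effect of an aryl substituent change on this amide, so no step size is known. Given that compound 1 gives 48000 nM and compound 3 gives 52500 nM with quite different acyl groups, the step from compound 1 to compound 4 is expected to be a 1.3-fold higher number from compound 1 to compound 4 (0.10 log units; within the scatter), within or near the scatter. Compound 4 is therefore estimated at 60000 nM, between 25000 nM and 150000 nM, with a fair chance that this assay reports only a limit.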

Compound 4, half-maximal inhibitory concentration: > 100000 nM
Compound 4: only a limit was reported (the forecaster's own chance of this, stated with the estimate: 25%); middle value at least 1.6-fold (0.22 log units) away from the limit.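

For the compounds shown here, the acyl group on the amide of the shared core is not neutral for activity: in this assay, 4-methoxyphenyl in place of 3-nitrophenyl on a carbonyl carbon gives an at least 2.0-fold higher number from compound 1 to compound 4 (0.31 log units; beyond the scatter), the first one-place comparison. Compound 4 gives > 100000 nM, a limit of the assay and not a number, so only a lower bound on the step can be read. The limit now also occurs on the shared core of compound 1 and compound 3, and not only with the different thioether heterocycle of compound 2: the limit of > 100000 nM in this assay, at which 2 of the 4 values shown sit.

The compounds shown leave open whether the step comes from losing 3-nitrophenyl or from gaining 4-methoxyphenyl. An unsubstituted phenyl or an aminophenyl group on the same carbonyl carbon would help to separate the two.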